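The compounds below may be only part of what the source reports. "The series", "measured", "known", "first", "only" and "open" are said of these compounds alone.

Series notes, step from compound 1 to compound 4.

Compound 1 `COc1cc(C(=O)Nc2nn[nH]n2)nc(-c2ccccc2)c1` is the reference point. In a functional assay on the whole organism for inhibition, with Rattus norvegicus as the target, at a dose of 10 mg/kg by the oral route (a higher number here means a stronger effect of the compound at the dose given, a lower number a weaker effect), compound 1 gives 100%. Compound 3 `COc1cc(C(=O)Nc2nn[nH]n2)nc(-c2ccc(NC(C)=O)cc2)c1` gives 100% in this assay, and the step of no change at the digits printed from compound 1 to compound 3 (within the scatter) leaves compound 1 level with compound 3, the two of them together at the top of the three numbers. Compound 2 `COc1cc(C(=O)Nc2nn[nH]n2)nc(-c2ccc(Cl)cc2)c1` gives 55% in this assay; the step of a number 45 percentage points lower from compound 1 to compound 2 (beyond the scatter) is the only drop among the measured compounds, and the step of a number 45 percentage points higher from compound 2 to compound 3 (beyond the scatter) recovers it.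

Compound 4 `CCCc1cc(C(=O)Nc2nn[nH]n2)nc(-c2ccccc2)c1` is not yet measured. It differs from compound 1 in one place: propyl in place of methoxy on an aromatic carbon. All three measured steps alter the group on the phenyl ring, whereas the change to compound 4 sits on the shared core. Among the compounds with values here, no measured step therefore bears on it directly; the measured steps show only that one change at a single place ranges from no effect to a large one. With compound 1 at the top of the scale, any movement for compound 4 can only be downward or absent, so a modest loss is expected. The step from compound 1 to compound 4 is expected to be a number 20 percentage points lower from compound 1 to compound 4 (beyond the scatter). Compound 4 is estimated at 80% in this assay, within a range of 40% to 100%.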

Compound 4, a percentage reported as inhibition, in the whole organism at one dose (the size of the read-out at that dose, not a potency): 85%
The estimate for compound 4 lay 5 percentage points below the measured number, and the stated range covers the measured number.
By their numbers in this assay, from the lowest: compound 2; then compound 4; then compounds 1 and 3 (each within the scatter of the next).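

The position opposite the ring nitrogen on the shared core is now shown to affect the read-out in this assay, as propyl in place of methoxy gives a number 15 percentage points lower from compound 1 to compound 4 (beyond the scatter) and the earlier steps all lay on the phenyl group. This change removes the one hydrogen-bond acceptor of methoxy and adds a carbon chain, yet compound 4 still reaches 85% at the single oral dose, so in this compound the methoxy oxygen is not required for a substantial effect, although the number is no measure of potency. No measurement available here bears on why this step occurs.

Going by these compounds, whether the modest loss goes with the absent oxygen or with the propyl chain stays open, and an ethoxy group, an ethyl group, a longer alkyl chain or an amine at this position would help to separate the two. Also open, on these data alone, is whether propyl on the core would leave the effects of chloro and acetamido on the phenyl group as they stand in compound 2 and compound 3 .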